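Series notes: benzyl removed from the aromatic nitrogen

The compounds below may be only part of what the source reports. "The series", "measured", "known", "first", "only" and "open" are said of these compounds alone.

Compound 1 `CC(C)(C)n1ccnc1/N=C(\N)Nc1ccc(Cl)c(Cl)c1` and compound 2 `N/C(=N\c1nccn1Cc1ccccc1)Nc1ccc(Cl)c(Cl)c1` share one core and differ only in the group on the aromatic nitrogen, benzyl in place of tert-butyl. In an in vitro ADME assay on microsomes from liver (Homo sapiens) for metabolic stability, read by LC-MS, tested at 1 uM (a higher number here means that the compound lasts longer, a lower number that the compound disappears faster), compound 1 gives > 1 h, a limit of the assay rather than a number. In this assay compound 2 gives > 1 h, again only a limit. Both readings thus sit at the limit of > 1 h in this assay, at which 2 of the 2 values shown sit, and the step that the two limits leave unreadable from compound 1 to compound 2 cannot be read in size or direction. Compound 3 `N/C(=N\c1ncc[nH]1)Nc1ccc(Cl)c(Cl)c1` is not yet measured; it differs from compound 2 by hydrogen in place of benzyl on an aromatic nitrogen. Within the data shown here, the one measured step, benzyl in place of tert-butyl on an aromatic nitrogen, bears on it as a change at the same place, but the two limits hide its size. No direction of shift in this assay can be drawn from the measured pair. Compound 3 is expected to stay near the measured pair, at an estimated 1.5 h within 0.5 h to 4 h, which would mean an expected step that the limit leaves unreadable from compound 2 to compound 3 and most probably again only a limit.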

Compound 3, half-life: 0.708 h
Estimate against measurement, compound 3: 2.1-fold (0.33 log units) above; the range from low to high includes it.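

Among these compounds, with hydrogen on the aromatic nitrogen, compound 3 gives the first reading at this position in this assay that is a number and not a limit. Hydrogen in place of benzyl gives an at least 1.4-fold lower number from compound 2 to compound 3 (0.14 log units; that floor lies within the scatter), and hydrogen in place of tert-butyl gives an at least 1.4-fold lower number from compound 1 to compound 3 (0.14 log units; that floor lies within the scatter), so neither large group is yet shown to set the reading apart from hydrogen by more than the scatter. The full size of these two steps stays hidden, and the step between the two substituted compounds still cannot be read: the limit of > 1 h in this assay, at which 2 of the 3 values shown sit.

Going by these compounds, how far compound 1 and compound 2 lie past their limit remains open, and with it whether either group truly outlasts hydrogen here. Also open, on these data alone, is how methyl, or a longer chain ending in an amine, would read at this place in this assay.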